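This account rests on a few compounds, and the source may have more. Where it says the series, first, only, none or still open, it means among the compounds named here.

Among the measured compounds shown here, compound 2 `C=CCN(C)C(=O)c1ccc(C(CC)(CC)c2ccc(OCC(=O)C(C)(C)C)c(C)c2)n1CC` is the weaker of the two compounds measured so far in an assay on HL-60 cells for agonist activity at vitamin D3 receptor (Homo sapiens), read by microscopy, with a stated time of 96 h; a higher number here means that more compound is needed for the effect, a lower number that less compound is needed. In this assay compound 2 gives 21600 nM, whereas compound 1 `CCn1c(C(=O)NCCN(C)C)ccc1C(CC)(CC)c1ccc(OCC(=O)C(C)(C)C)c(C)c1` gives 77 nM. For the measured compounds named here, the single step between them, a 280-fold higher number from compound 1 to compound 2 (2.45 log units; beyond the scatter), shows how strongly the group on the carbonyl carbon matters.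

Compound 3 `CCOC(=O)CC(C)OC(=O)c1ccc(C(CC)(CC)c2ccc(OCC(=O)C(C)(C)C)c(C)c2)n1CC` has not yet been measured. It differs from compound 2 by a group of 9 heavy atoms (6 carbon, 3 oxygen; no ring) in place of a group of 5 heavy atoms (4 carbon, 1 nitrogen; no ring), on a carbonyl carbon. Like compound 2, it carries no nitrogen and no hydrogen-bond donor in that group; the one measured step points to a large loss when such a group replaces the (2-(dimethylamino)ethyl)amino of compound 1, but gives no guide to an exchange between two groups that both lack it. Compound 3 is therefore expected to stay close to compound 2, with a 1.4-fold lower number from compound 2 to compound 3 (0.16 log units; within the scatter) as the estimated step. The estimate for compound 3 is 15000 nM, within a range from 3000 nM to 80000 nM.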

Compound 3, half-maximal effective concentration: > 50000 nM
Compound 3 ended at the assay's limit; the forecaster's own chance of this, stated with the estimate: 25%; middle value at least 3.3-fold (0.52 log units) from the limit.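

The reading for compound 3 is a limit and not a number: the limit of > 50000 nM in this assay, at which 1 of the 3 values shown sits. Even so, it shows that this carbonyl carbon remains sensitive when one group lacking the (2-(dimethylamino)ethyl)amino of compound 1 replaces another, with an at least 2.3-fold higher number from compound 2 to compound 3 (0.36 log units; beyond the scatter). Set against the best compound shown, the change is an at least 640-fold higher number from compound 1 to compound 3 (2.81 log units; beyond the scatter), so neither of the two replacements comes close to compound 1 in this assay.

The compounds shown do not reveal how much further compound 3 would lie beyond the limit, or which part of the (2-(dimethylamino)ethyl)amino group goes with the much lower number of compound 1. A simple primary amine, a longer chain ending in a dimethylamino group, or a carboxylic acid on this carbonyl carbon would each add evidence on that question.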